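The source may hold more compounds than are shown below. What is called first, only, known or untested is meant among the compounds shown, and "the series" means these compounds.

In an ADME assay on HEK293 cells (Homo sapiens) for cytotoxicity, read by luminescence, with a stated time of 72 h (a lower number here means that less compound is needed, a higher number that more compound is needed for the effect), compound 1, `CCOC(=O)c1c(-c2cccc(OCc3ccccc3)c2)[nH]c2cc(OC)ccc2c1=O`, gives > 22000 nM, which is a limit of the assay and not a number. Compound 2, `CCOC(=O)c1c(-c2cccc(OC(F)(F)F)c2)[nH]c2cc(OC)ccc2c1=O`, gives > 22000 nM, which is likewise a limit. Going by the values given here, the one measured comparison is a step that the two limits leave unreadable from compound 1 to compound 2, where trifluoromethyl takes the place of benzyl on an oxygen on an aromatic ring. From the compounds shown here alone, compound 2 therefore stands with compound 1 at the limit of > 22000 nM in this assay, at which 2 of the 2 values shown sit, and its true position beyond that limit is unknown.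

Compound 3, `CCOC(=O)c1c(-c2cccc(OC(F)(F)F)c2)[nH]c2cc(C(F)(F)F)ccc2c1=O`, keeps the trifluoromethyl group of compound 2 on the oxygen and changes the shared core: trifluoromethyl replaces methoxy on an aromatic carbon, (trifluoromethyl in place of methoxy on an aromatic carbon). Among the compounds with values here, no measured step covers this place, and the only step available has no readable size, so it offers no basis for expecting a shift in either direction in this assay. The expectation rests only on (the limit of > 22000 nM in this assay, at which 2 of the 2 values shown sit), and no step beyond the scatter is expected. The estimated step is a step that the limit leaves unreadable from compound 2 to compound 3. For compound 3 the expected value is 25000 nM, with an estimated range from 11000 nM to 50000 nM.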

Compound 3, half-maximal effective concentration: > 22000 nM
Compound 3: a limit, no number (the forecaster's own chance of this, stated with the estimate: 75%); the middle value is on the limit's open side.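

In this assay compound 3 gives > 22000 nM, which is a limit of the assay and not a number. Compound 2 also stands at a limit, and the step between compound 2 and compound 3 cannot be read. The compounds shown leave open where each truly lies, and whether either exchange changes the value at all: the limit of > 22000 nM in this assay, at which 3 of the 3 values shown sit.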